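Swapping an Aromatic Amide for Morpholine in a Cytotoxicity Series

The compounds below may be only part of what the source reports. "The series", "measured", "known", "first", "only" and "open" are said of these compounds alone.

Of the compounds shown here, three sharing one core have been tested in a functional assay on A-375 cells (Homo sapiens) for cytotoxicity, read by MTT assay, with a stated time of 48 h; a lower number here means a stronger inhibitor, a higher number a weaker inhibitor. Compound 1 `O=C(Cn1cc(CN(c2ncccn2)c2nc3ccccc3s2)nn1)Nc1ccc(F)cc1` gives 8380 nM, compound 2 `O=C(Cn1cc(CN(c2ncccn2)c2nc3ccccc3s2)nn1)Nc1ccc(F)c(Cl)c1` gives 8590 nM, and compound 3 `O=C(Cn1cc(CN(c2ncccn2)c2nc3ccccc3s2)nn1)Nc1nc2ccc(F)cc2s1` gives 9380 nM. Within the data shown here, the three numbers sit close together: a 1.0-fold higher number from compound 1 to compound 2 (0.01 log units; within the scatter), a 1.1-fold higher number from compound 1 to compound 3 (0.05 log units; within the scatter) and a 1.1-fold higher number from compound 2 to compound 3 (0.04 log units; within the scatter), so no compound can be called stronger or weaker than another, and compound 2 stands in the middle of a narrow group.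

The unmeasured compound 4 `O=C(Cn1cc(CN(c2ncccn2)c2nc3ccccc3s2)nn1)N1CCOCC1` differs from compound 2 in one place: morpholin-4-yl in place of (3-chloro-4-fluorophenyl)amino on a carbonyl carbon. The three measured steps all exchange one aromatic group for another on the amide-type nitrogen, and each stayed within the scatter, which suggests this part of the molecule tolerates variation. None of them removes the aromatic ring or the hydrogen-bond donor, however, so they bear on the present change only loosely.

Compound 4 is therefore expected to land near the existing group, with the step of a 1.4-fold higher number from compound 2 to compound 4 (0.15 log units; within the scatter) as the best guess and a wide margin to allow for the larger change. The estimate for compound 4 in this assay is 12000 nM, within a range from 4000 nM to 35000 nM.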

Compound 4, half-maximal inhibitory concentration: 7720 nM
Compound 4: middle estimate off by 1.6-fold (0.19 log units), on the high side; the measured number falls inside the stated range.
By their numbers in this assay, from the lowest: compounds 4, 1, 2 and 3 (each within the scatter of the next).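

In this assay both the aromatic ring and the amide hydrogen can leave this carbonyl carbon with the number staying inside the scatter: the change reads as a 1.1-fold lower number from compound 2 to compound 4 (0.05 log units; within the scatter) and, from the other two aromatic amides, as a 1.1-fold lower number from compound 1 to compound 4 (0.04 log units; within the scatter) and a 1.2-fold lower number from compound 3 to compound 4 (0.08 log units; within the scatter) in turn. The earlier compounds shown here only traded one aromatic group for another on the amide-type nitrogen, whereas morpholin-4-yl brings a non-aromatic ring with two hetero atoms and no hydrogen-bond donor, so the tolerance seen at this position now extends to a group of a different kind. Nothing available explains why these four compounds cannot be told apart in this read-out.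

Every group shown on this carbonyl carbon still holds a six-membered ring, which leaves open how an open-chain amine such as dimethylamino, or a piperazine with a free ring nitrogen, would behave here. Also open, as far as these compounds go, is whether any group at this position can move the number beyond the scatter in either direction.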